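Removing an acetyl from a sulfonamide antiproliferative

A few compounds are considered here, and "the series" means these few. Any claim that something is new, unique, unknown or untested is made for them only; others in the source may bear on it.

Measured compounds:
compound 1 `CC(=O)Oc1ccc(CONC(=O)c2ccc(CS(=O)(=O)Nc3ccc4cc(C)c(=O)n(C)c4c3)cc2)cc1`: 91%
compound 2 `Cc1cc2cc(NS(=O)(=O)c3cc(C(=O)NO)ccc3Cl)ccc2n(C)c1=O`: 21%
compound 3 `COC(=O)c1ccc(CS(=O)(=O)Nc2ccc3c(c2)cc(C)c(=O)n3C)cc1`: 93%

The three compounds share one core and were tested in a functional assay on THP-1 cells (Homo sapiens) for antiproliferative activity, tested at 100 uM; on this read-out higher numbers stand for a stronger effect at the one concentration tested and lower numbers for a weaker effect. On the numbers shown, compound 1 sits at the upper end together with compound 3, and the gap between them is within the usual scatter of repeated measurements, so no order between the two can be claimed. Compound 2 lies far below both, beyond the scatter. No direct step between any pair of these compounds has been worked out, so only the bare values can be compared.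

Compound 4 `Cc1cc2ccc(NS(=O)(=O)Cc3ccc(C(=O)NOCc4ccc(O)cc4)cc3)cc2n(C)c1=O` is the next compound in line. It differs from compound 1 in one place: hydrogen in place of acetyl on an oxygen on an aromatic ring. The change is small in size, a hydrogen in place of acetyl, and it sits at the far end of the molecule from the core.

Going by the values given here, there is no measured step to lean on. Still, the gap between compound 1 and compound 3, which lies within the scatter, suggests this outer end of the molecule tolerates variation without much loss in this assay. The step from compound 1 to compound 4 is expected to be modest, a number 6 percentage points lower from compound 1 to compound 4 (within the scatter), and not clearly beyond the scatter. Compound 4 is therefore estimated to give 85%, in a range from 65% to 97%.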

Compound 4, a percentage reported as inhibition, at one concentration (the size of the read-out at that concentration, not a potency): 91%
Estimate against measurement, compound 4: 6 percentage points below, and the stated range covers the measured number.
By their numbers in this assay, from the lowest: compound 2; then compounds 1, 4 and 3 (each within the scatter of the next).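

In this assay, going by these compounds alone, the change from 4-acetoxyphenyl to 4-hydroxyphenyl gives no change at the digits printed from compound 1 to compound 4 (within the scatter), the first direct one-place comparison in this set. Earlier, the tolerance of this outer end could only be inferred from compounds that differ in more than one place, whereas here the acetyl on the oxygen can leave, with only a hydrogen in its place, and the read-out at this one concentration stays where it was. No supporting measurement is available to explain this outcome.

A single replacement on this oxygen cannot show how far that tolerance extends: a methyl group on the same oxygen, or an amine or a carboxylic acid in place of the hydroxy group, would test whether the result is specific to these two end groups. Since the read-out gives the size of the effect at one concentration and is not a potency, a full concentration series on compound 1 and compound 4 would be needed to tell whether the two also match at lower concentrations.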